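Replacing cyclopropyl with (furan-2-yl)methyl: a step without a guide

The compounds below may be only part of what the source reports. "The series", "measured", "known", "first", "only" and "open" are said of these compounds alone.

For the measured compounds named here, in an ADME assay on J774.A1 cells (Mus musculus) for inhibition, read by MTT assay, with a stated time of 72 h (on this read-out lower numbers stand for an effect already at smaller amounts and higher numbers for an effect only at larger amounts of compound), the three compounds tested so far offer little to build on. Compound 1 `CNc1nc(NCc2ccco2)nc2ccccc12` has the entry "not determined" (no result reported) and so offers no number. Compound 2 `CC(C)Nc1nc(NC(C)C)c2ccccc2n1` shows only the limit > 30000 nM and no exact value. Compound 3 `CC(C)Nc1nc(NC2CC2)nc2ccccc12` likewise shows only the limit > 40000 nM and no exact value, so the starting point is not a true number.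

Compound 4 `CC(C)Nc1nc(NCc2ccco2)nc2ccccc12` is still unmeasured. The change leading to it is (furan-2-yl)methyl in place of cyclopropyl on a nitrogen on an aromatic ring and amounts to (furan-2-yl)methyl in place of cyclopropyl on a nitrogen on an aromatic ring. Going by the values given here, the one measured step that bears on this is a step that the two limits leave unreadable from compound 2 to compound 3 and it puts cyclopropyl in place of isopropyl on such a nitrogen, yet it gives no size to carry over. No clear step in either direction is therefore expected in this assay and the estimated move is an at least 1.1-fold lower number from compound 3 to compound 4 (0.05 log units; that floor lies within the scatter) with a good chance of another limit. For compound 4 the estimated value is 35000 nM with 12000 nM to 80000 nM as the expected span.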

Compound 4, half-maximal effective concentration: 8300 nM
Compound 4: middle estimate off by 4.2-fold (0.62 log units), on the high side; measured number outside the range, below it.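

In this assay, the nitrogen on an aromatic ring proves to be a place where the group matters: (furan-2-yl)methyl in place of cyclopropyl gives an at least 4.8-fold lower number from compound 3 to compound 4 (0.68 log units; beyond the scatter). Set against the isopropyl of compound 2, the same group gives an at least 3.6-fold lower number from compound 2 to compound 4 (0.55 log units; beyond the scatter), so compound 4 now provides the first exact value and a first real reference point in the series. Both steps are minimum sizes, and the true gaps may be larger, as each one starts from a limit rather than a number, as with compound 3: the limit of > 40000 nM in this assay, at which 1 of the 4 values shown sits.

From the compounds shown here alone, whether the ring oxygen of the furan plays any part stays open: a benzyl group, with a ring of carbon only, would be the direct comparison. Going by these compounds, how a longer chain between the nitrogen and the furan would read also remains open.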